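Chloro to iodo in the sulfoamino series

This account rests on a few compounds, and the source may have more. Where it says the series, first, only, none or still open, it means among the compounds named here.

Measured so far in a physicochemical assay for lipophilicity, measured as octanol-water partition, at pH 7.4; on this read-out lower numbers stand for lower lipophilicity and higher numbers for higher lipophilicity:
- compound 1 `Cc1cc(-c2nc3ccccc3s2)ccc1NS(=O)(=O)O`: 0.6
- compound 2 `O=S(=O)(O)Nc1ccc(-c2nc3ccccc3s2)cc1Cl`: 0.02

Compound 2 stands lowest of the two measured compounds, at 0.02, while compound 1 gives 0.6. Next is compound 3 `O=S(=O)(O)Nc1ccc(-c2nc3ccccc3s2)cc1I`, still unmeasured in this assay. It differs from compound 2 as follows: iodo in place of chloro on an aromatic carbon. Going by the values given here, one measured step bears on this change: a number 0.58 log units lower from compound 1 to compound 2 (beyond the scatter), with chloro in place of methyl on an aromatic carbon. Iodo occurs in no measured compound, so this single step offers a scale for a swap of one group on an aromatic carbon, but it does not fix a direction. The upward direction is therefore a judgement that the series has not yet tested, and a modest size is expected on the scale of a number 0.58 log units lower from compound 1 to compound 2 (beyond the scatter). The expected change is a number 0.38 log units higher from compound 2 to compound 3 (beyond the scatter). For compound 3 the estimated value is 0.4, with an expected range from 0 to 0.8.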

Compound 3, distribution coefficient: 1.8
For compound 3 the middle estimate is 1.40 log units below the measured one, and the stated range ends below it.
By their numbers in this assay, from the lowest: compound 2; then compound 1; then compound 3.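

In this assay, the position ortho to a sulfoamino group responds strongly to a swap of one halogen for another: a number 1.78 log units higher from compound 2 to compound 3 (beyond the scatter) is a large step, and it runs opposite in direction to a number 0.58 log units lower from compound 1 to compound 2 (beyond the scatter) in the earlier pair. Methyl therefore no longer holds the top of the series, since a number 1.20 log units higher from compound 1 to compound 3 (beyond the scatter) places iodo above both other groups, giving the order chloro, methyl, iodo from the lowest number upward. Chloro and iodo are alike in the computed counts, each with 1 heavy atom and with 0 hydrogen-bond donors and 0 hydrogen-bond acceptors, so these counts do not separate them, and nothing at hand explains the size of the step.

Still open, as far as these compounds go, is where bromo and fluoro would fall on this position relative to chloro and iodo, and so whether the halogens form a steady progression or iodo stands apart. Also open, from the compounds shown here alone, is whether a step of this size from chloro to iodo would persist on the same core with a carboxylic acid in place of the sulfoamino group.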